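Adding a methyl to a benzyl group of compound 1

A few compounds are considered here, and "the series" means these few. Any claim that something is new, unique, unknown or untested is made for them only; others in the source may bear on it.

Values so far in a functional assay on Cortical neurone cells (Mus musculus, strain C57BL/6), read by FLIPR and calcium flux, with a stated time of 8 min; on this read-out higher numbers stand for weaker inhibition and lower numbers for stronger inhibition

- compound 1 `O=c1cc(Cc2ccccc2)[nH]c2nc(Cc3ccc(Cl)cc3)nn12` gives 4280 nM
- compound 2 `Cc1ccc(Cc2nc3[nH]c(Cc4ccccc4)cc(=O)n3n2)cc1` gives 2470 nM

Compound 1 cannot be ranked against compound 2 on these two numbers. Among the measured compounds shown here, the only measured step is a 1.7-fold lower number from compound 1 to compound 2 (0.24 log units; within the scatter) and it places compound 1 level with its sole neighbour. Compound 3 `Cc1ccc(Cc2cc(=O)n3nc(Cc4ccc(Cl)cc4)nc3[nH]2)cc1` has not yet been measured. It departs from compound 1 at the benzyl group that becomes 4-methylbenzyl, with methyl in place of hydrogen on an aromatic carbon, as counted here: methyl in place of hydrogen on an aromatic carbon and the chloro group stays in place.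

For the measured compounds named here, no measured pair tests this change directly. Going by the values given here, the one measured step bears on it only loosely, since it also brings in a methyl on an aromatic carbon, though at another site and in exchange for chloro. Among the compounds with values here, with a 1.7-fold lower number from compound 1 to compound 2 (0.24 log units; within the scatter) as the only guide, no shift beyond the scatter is expected in this assay and no direction can be favoured. The expected step is a 1.2-fold lower number from compound 1 to compound 3 (0.09 log units; within the scatter) and it rests on this single comparison. Compound 3 is estimated at 3500 nM with an expected range from 1300 nM to 9000 nM for a first measurement.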

Compound 3, half-maximal inhibitory concentration: 3020 nM
Compound 3: middle estimate off by 1.2-fold (0.06 log units), on the high side; low and high end bracket the measured number.
By their numbers in this assay, from the lowest: compounds 2, 3 and 1 (each within the scatter of the next).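

In this assay, among the compounds shown here, the benzyl group without chlorine in compound 1 is now probed directly for the first time: 4-methylbenzyl replacing benzyl gives a 1.4-fold lower number from compound 1 to compound 3 (0.15 log units; within the scatter), with the methyl para to a large group and the chloro group left in place. Compound 2 had only tested the other benzyl group, where methyl in place of chloro gave a 1.7-fold lower number from compound 1 to compound 2 (0.24 log units; within the scatter), so a single methyl has now been read at each of the two sites, and neither step lies beyond the scatter. No measurement at hand explains the size of the new step, and nothing measured on these compounds bears on it.

Still open is whether any substituent at this position can move the number beyond the scatter, since methyl is the only one shown there and groups such as a carboxylic acid, a primary amine or a longer chain like butyl would test this far more severely. Also open, from the compounds shown here alone, is how the two sites behave together, which a compound carrying 4-methylbenzyl at both would address.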